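Lengthening a Side Chain on Two Protected Sugar Cores

The source may report more compounds than this note shows. Statements on the series, on what has been measured and on what is new or still open speak of the compounds shown alone.

All three measured compounds were tested in a functional assay on HeLa cells (Homo sapiens) for antiproliferative activity, read by sulforhodamine B assay; a lower number here means a stronger inhibitor of growth, a higher number a weaker inhibitor of growth:

Compound 1 `CCC[C@@H]1O[C@H](COCc2ccccc2)[C@@H](OCc2ccccc2)[C@H](OCc2ccccc2)[C@H]1O` gives 18900 nM.
Compound 2 `CCCC[C@@H]1O[C@H](COCc2ccccc2)[C@@H](OCc2ccccc2)[C@H](OCc2ccccc2)[C@H]1O` gives > 50000 nM.
Compound 3 `CC[C@@H]1O[C@H](COCc2ccccc2)[C@@H](OCc2ccccc2)[C@H](OCc2ccccc2)C1=O` gives > 50000 nM.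

The number for compound 2 is a limit of the assay, not a measured value. The number for compound 3 is likewise a limit. Compound 2 differs from compound 1 by methyl in place of hydrogen on a saturated chain carbon, three bonds along the chain from a saturated ring carbon. Across that change the inhibitor becomes weaker: an at least 2.6-fold higher number from compound 1 to compound 2 (0.42 log units; beyond the scatter). How the core of compound 3 differs from the core of compound 1 is not broken down here.

Compound 4 `CCC[C@@H]1O[C@H](COCc2ccccc2)[C@@H](OCc2ccccc2)[C@H](OCc2ccccc2)C1=O` has not been measured. It differs from compound 3 by methyl in place of hydrogen on a saturated chain carbon, two bonds along the chain from a saturated ring carbon. This is the same kind of change as the one between the first two compounds, but not the same: there the entering methyl sits three bonds along the chain from a saturated ring carbon, here two bonds along the chain from a saturated ring carbon. Among the compounds with values here, the one measured instance of this kind of change lowered potency, and compound 3 already sits at the edge of what the assay reports, as the limit of > 50000 nM in this assay, at which 2 of the 3 values shown sit, shows. The expected step in this assay is a step that the limit leaves unreadable from compound 3 to compound 4, small and most likely ending again at a limit. Compound 4 is estimated to give 60000 nM in this assay, with a plausible range from 20000 nM to 150000 nM.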

Compound 4, concentration for 50% growth inhibition: > 50000 nM
Compound 4: no number, only a limit; the forecaster's own chance of this, stated with the estimate: 70%; the middle value lies beyond the limit too.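

In this assay compound 4 gives > 50000 nM, which is a limit of the assay and not a number. Compound 3 also stands at a limit, so the size of the change between compound 3 and compound 4 cannot be read: the limit of > 50000 nM in this assay, at which 3 of the 4 values shown sit.

The compounds shown leave open whether going from ethyl to propyl on this core changes growth inhibition at all.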